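The source may hold more compounds than are shown below. What is called first, only, known or untested is meant among the compounds shown, and "the series" means these compounds.

In a functional assay on HL-60 cells (Homo sapiens), with a stated time of 2 days (on this read-out lower numbers stand for stronger inhibition and higher numbers for weaker inhibition), compound 2 (`Cc1ccc(CNC(=O)c2[nH]cnc2C(=O)Nc2ccc(Cl)c(Cl)c2)cc1`) gives 21400 nM and so sits within the scatter of compound 1 (`O=C(NC1CCCCC1)c1nc[nH]c1C(=O)Nc1ccc(Cl)c(Cl)c1`) at 33100 nM on this scale. Compound 3 (`O=C(NCc1ccc(-c2ccccc2)cc1)c1nc[nH]c1C(=O)Nc1ccc(Cl)c(Cl)c1`) at 7000 nM has a lower number than compound 2, and that gap lies beyond the scatter.

Compound 4 (`C[C@H](NC(=O)c1[nH]cnc1C(=O)Nc1ccc(Cl)c(Cl)c1)C(=O)OC(C)(C)C`) has yet to be measured. Its difference from compound 2 is counted as 1-(tert-butoxycarbonyl)ethyl in place of 4-methylbenzyl on an amide-type nitrogen and, in words, it carries 1-(tert-butoxycarbonyl)ethyl in place of 4-methylbenzyl on an amide-type nitrogen.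

Among the compounds with values here, no two measured compounds differ in only one place, so no measured step offers a direct guide. The nearest hint is compound 1, which also has no aromatic ring in the group on that nitrogen, yet at 33100 nM stays within the scatter of compound 2. In this assay a small step toward weaker inhibition is therefore expected, one that probably stays within the scatter. The estimate amounts to an expected step of a 1.4-fold higher number from compound 2 to compound 4 (0.15 log units; within the scatter) in this set. Compound 3 at 7000 nM shows that values here can spread, so the range should stay wide. For compound 4 the estimate is 30000 nM with an expected range from 11000 nM to 85000 nM on this read-out.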

Compound 4, half-maximal inhibitory concentration: 4900 nM
Estimate against measurement, compound 4: 6.1-fold (0.79 log units) above; the whole stated range lies above it.
By their numbers in this assay, from the lowest: compounds 4 and 3 (each within the scatter of the next); then compounds 2 and 1 (each within the scatter of the next).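

In this assay the swap of 4-methylbenzyl for 1-(tert-butoxycarbonyl)ethyl on the amide-type nitrogen gives a 4.4-fold lower number from compound 2 to compound 4 (0.64 log units; beyond the scatter) and this step lies beyond the scatter. Within the data shown here, it is the first change in this set made at a single place, so it shows that this nitrogen's group can alter the read-out on its own, with the rest of the molecule held constant. It also shows that a group with no ring at this position can give a lower number than the 4-methylbenzyl group, even though one swap removes the aromatic ring and brings in an ester, with its two hydrogen-bond acceptors, and a defined stereocentre all at once.

The compounds shown leave open what would happen if a carboxylic acid or a methyl ester replaced the tert-butyl ester, or if a plain ethyl chain replaced the whole group, and such compounds could begin to separate these features. As things stand, no measurement here connects the step to any one of those features, so its origin remains unexplained.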